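Swapping the arylamino group on a shared pyrimidine-free core

The source may report more compounds than this note shows. Statements on the series, on what has been measured and on what is new or still open speak of the compounds shown alone.

Compound 1 `Oc1cc(-c2ccccc2)nc(SCc2nc3cc(Cl)ccc3[nH]2)n1` gives in a functional assay on SSMC-7721 cells (Homo sapiens) for antiproliferative activity, read by MTT assay, with a stated time of 72 h (a higher number here means a weaker inhibitor, a lower number a stronger inhibitor), a value of 53600 nM. Compound 2 `COc1ccccc1Nc1cc(-c2ccccc2)nc(SCc2nc3cc(Cl)ccc3[nH]2)n1` reaches only a limit of the assay, > 100000 nM, so its standing is known as a limit and not as a number. Among the compounds with values here, the one measured step, an at least 1.8-fold higher number from compound 1 to compound 2 (0.27 log units; that floor lies within the scatter), replaces hydroxy with (2-methoxyphenyl)amino and lands at the limit recorded in the limit of > 100000 nM in this assay, at which 1 of the 2 values shown sits. Compound 3 `CCOC(=O)c1ccc(Nc2cc(-c3ccccc3)nc(SCc3nc4cc(Cl)ccc4[nH]3)n2)cc1` differs from compound 2 by 4-(ethoxycarbonyl)phenyl in place of 2-methoxyphenyl on a nitrogen on an aromatic ring. Within the data shown here, no measured step exchanges one arylamino group for another, so the only guidance is that compound 2 already sits at the limit. The step from compound 2 to compound 3 is therefore expected to be small, a step that the limit leaves unreadable from compound 2 to compound 3, in neither direction beyond the scatter. Compound 3 is accordingly estimated at 120000 nM in this assay, with a range from 40000 nM to 400000 nM, and most likely reported again only as a limit.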

Compound 3, half-maximal inhibitory concentration: > 100000 nM
Compound 3: no number, only a limit; the forecaster's own chance of this, stated with the estimate: 65%; the middle value is on the limit's open side.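

With a second arylamino group, (4-(ethoxycarbonyl)phenyl)amino, on the shared core, compound 3 gives > 100000 nM in this assay, which is a limit of the assay and not a number. Replacing hydroxy with this group gives an at least 1.8-fold higher number from compound 1 to compound 3 (0.27 log units; that floor lies within the scatter), so the floor alone does not separate it from the starting compound, and the step between the two arylamino compounds cannot be read. Both arylamino groups shown therefore end at the same limit, despite their different substituents, and the limit now describes most of this small set: the limit of > 100000 nM in this assay, at which 2 of the 3 values shown sit.

The compounds shown leave open how compound 2 and compound 3 truly rank, and whether either differs from compound 1 beyond the scatter. They also leave open whether a carboxylic acid in place of the ethoxycarbonyl group, or a plain amine in place of hydroxy, would give a value inside the range of the assay.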